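This account rests on a few compounds, and the source may have more. Where it says the series, first, only, none or still open, it means among the compounds named here.

Measured so far in a functional assay on DU-145 cells (Homo sapiens) for inhibition, read by sulforhodamine B assay, with a stated time of 48 h; a higher number here means a weaker inhibitor of growth, a lower number a stronger inhibitor of growth:
compound 1, `COc1cc(-c2nn(-c3cccc(NC(=O)Nc4cc(C(F)(F)F)cc(C(F)(F)F)c4)c3)cc2-c2ccncc2)ccc1Cl`: 5040 nM
compound 2, `COc1cc(-c2nn(-c3cccc(NC(=O)Nc4ccc(Cl)c(Cl)c4)c3)cc2-c2ccncc2)ccc1Cl`: 34200 nM

Compound 2 stands at the highest of the two numbers; the nearest is compound 1, whose number is lower by a gap beyond the usual scatter. Among the compounds with values here, no pair of measured compounds that differ in a single place is available, so the two values show only that the urea end of compound 1 is matched by a clearly lower number than the urea end of compound 2.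

Compound 3, `COc1cc(-c2nn(-c3cccc(NC(=O)Nc4cccc(C(F)(F)F)c4)c3)cc2-c2ccncc2)ccc1Cl`, has not yet been measured in this assay. It differs from compound 2 in one place: 3-(trifluoromethyl)phenyl in place of 3,4-dichlorophenyl on an amide-type nitrogen. The group that enters carries one trifluoromethyl, where the corresponding group in compound 1 carries two, on an amide-type nitrogen whose other neighbour is the carbonyl carbon.

Within the data shown here, with no single-change step measured, the expectation for the step from compound 2 to compound 3 rests on the gap between compound 2 and compound 1: a move downward in this assay, beyond the scatter but not necessarily the whole distance, is expected, a 2.9-fold lower number from compound 2 to compound 3 (0.45 log units; beyond the scatter). For compound 3 the number expected is 12000 nM, within a range from 4000 nM to 40000 nM.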

Compound 3, concentration for total growth inhibition: > 50000 nM
Compound 3 ended at the assay's limit; the forecaster's own chance of this, stated with the estimate: 5%; at least 4.1-fold (0.61 log units) between middle value and limit.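

In this assay, compound 3 gives > 50000 nM, which is a limit of the assay and not a number. The series now has its first reading of a single change on the urea aryl group, hydrogen in place of trifluoromethyl on an aromatic carbon, and it gives an at least 9.9-fold higher number from compound 1 to compound 3 (0.99 log units; beyond the scatter), so in this series the second trifluoromethyl of compound 1 goes with a clearly lower number. The other change, 3-(trifluoromethyl)phenyl in place of 3,4-dichlorophenyl on an amide-type nitrogen, gives an at least 1.4-fold higher number from compound 2 to compound 3 (0.16 log units; that floor lies within the scatter), and since that floor lies within the scatter, this step does not establish a real difference, and its true size stays unknown: the limit of > 50000 nM in this assay, at which 1 of the 3 values shown sits.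

The compounds shown leave open whether the lower number of compound 1 is specific to trifluoromethyl, or whether a chlorine, a methyl or a nitrile on the same aromatic carbon would serve as well. They also leave open how far compound 3 really lies from compound 2, and whether the steps read here would hold with an amine or a carboxylic acid on the same aryl group.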